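A few compounds are considered here, and "the series" means these few. Any claim that something is new, unique, unknown or untested is made for them only; others in the source may bear on it.

Compound 1: `O=C(c1ccc(F)c(F)c1)N1CC(c2nc(-c3cccc(F)c3)no2)C1`, 3200 nM
Compound 2: `COC1CCCN(C(=O)N2CC(c3nc(-c4cccc(Cl)c4)no3)C2)C1`, > 10000 nM
Compound 3: `O=C(C1CCC(C(F)(F)F)CC1)N1CC(c2nc(-c3cccc(Cl)c3)no2)C1`, 1000 nM

Three compounds sharing one core were tested in an assay on HEK293 cells for positive allosteric modulation of metabotropic glutamate receptor 5 (Homo sapiens), read by FLIPR; a higher number here means that more compound is needed for the effect, a lower number that less compound is needed. Compound 1 gives 3200 nM, the highest of the two numbers found in this assay. Compound 3 gives 1000 nM in this assay, a lower number than compound 1 by a margin beyond the usual scatter. Compound 2 reaches only a limit, (the limit of > 10000 nM in this assay, at which 1 of the 3 values shown sits), in this assay, so no number is known for it.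

Compound 4, `O=C([C@@H]1CC2CCC1C2)N1CC(c2nc(-c3cccc(F)c3)no2)C1`, has not yet been measured in this assay. It differs from compound 1 in one place: a group of 7 heavy atoms (7 carbon; 2 five-membered non-aromatic rings of carbon only) in place of a group of 8 heavy atoms (6 carbon, 2 fluorine; one six-membered aromatic ring of carbon only), on a carbonyl carbon. For the measured compounds named here, no step between two measured compounds that differ in a single place is available here, so the size of this change cannot be read off directly. The expectation for compound 4 in this assay is a modest move toward a lower number, a 1.6-fold lower number from compound 1 to compound 4 (0.20 log units; within the scatter), a step that may or may not exceed the scatter, leaning on compound 3 giving 1000 nM. Compound 4 is therefore estimated at 2000 nM, within a range from 600 nM to 8000 nM.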

Compound 4, half-maximal effective concentration: 100 nM
The estimate for compound 4 lay 20-fold (1.30 log units) above the measured number; the whole stated range lies above it.
By their numbers in this assay, from the lowest: compound 4; then compound 3; then compound 1. At a limit, above all of these: compound 2.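

In this assay, the group on the carbonyl carbon turns out to matter a great deal: putting the group of 2 five-membered non-aromatic carbon rings in place of the 3,4-difluorophenyl gives a 32-fold lower number from compound 1 to compound 4 (1.51 log units; beyond the scatter). For the compounds shown here, this is the first step between two measured compounds that differ in one place, so the size of a change here can now be read directly, and it is large. An aromatic ring on this carbonyl carbon is therefore not needed for a low number in compound 4, and the step comes with no change in the count of hydrogen-bond donors or acceptors or in net charge.

Nothing shown explains why this step is so large. On these data alone, whether a tert-butyl group or a pyridine ring on the same carbonyl carbon would give a similar number remains open, as does the role of the defined stereocentre in the entering group.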